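Chloro on the benzoyl ring of compound 2

The compounds below may be only part of what the source reports. "The series", "measured", "known", "first", "only" and "open" are said of these compounds alone.

Compound 1 `COc1cc(N(Cc2nc3ccccc3[nH]2)S(=O)(=O)c2ccccc2)cc(OC)c1OC` gives 12400 nM in a functional assay on MGC-803 cells (Homo sapiens) for inhibition, read by MTT assay, with a stated time of 48 h; a higher number here means a weaker inhibitor, a lower number a stronger inhibitor. Compound 2 `COc1cc(N(Cc2nc3ccccc3[nH]2)C(=O)c2ccccc2)cc(OC)c1OC` reaches only a limit in this assay, where compound 2 gives > 50000 nM. The step of an at least 4.0-fold higher number from compound 1 to compound 2 (0.60 log units; beyond the scatter) lay beyond the scatter. What is known of compound 2 is the limit of > 50000 nM in this assay, at which 1 of the 2 values shown sits. Compound 3 `COc1cc(N(Cc2nc3ccccc3[nH]2)C(=O)c2cccc(Cl)c2)cc(OC)c1OC` differs from compound 2 by chloro in place of hydrogen on an aromatic carbon, meta to a large group. For the measured compounds named here, no measured step touches this change; the single step in hand concerns the group on the nitrogen, not the benzoyl ring. A value at or near the limit is therefore expected for compound 3, with the step of a number no higher from compound 2 to compound 3 (the limit leaves the size open) estimated as none beyond the scatter. The estimate for compound 3 is 50000 nM, between 15000 nM and 150000 nM.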

Compound 3, half-maximal inhibitory concentration: > 50000 nM
Compound 3 ended at the assay's limit (the forecaster's own chance of this, stated with the estimate: 70%); the middle value lies on the limit itself.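

In this assay compound 3 gives > 50000 nM, which is a limit of the assay and not a number. The step for chloro on the benzoyl ring cannot be read, while the change from phenylsulfonyl to (3-chlorophenyl)carbonyl gives an at least 4.0-fold higher number from compound 1 to compound 3 (0.60 log units; beyond the scatter). With chloro in place, the benzoyl series still yields no readable value: the limit of > 50000 nM in this assay, at which 2 of the 3 values shown sit.

Going by these compounds, whether an amine or a carboxylic acid on the benzoyl ring would bring a value inside the readable range stays open. Also open, on these data alone, is what chloro does on the phenylsulfonyl ring of compound 1, where a number can be read.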